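A few compounds are considered here, and "the series" means these few. Any claim that something is new, unique, unknown or untested is made for them only; others in the source may bear on it.

Of the compounds shown here, three have been measured in a functional assay on NUGC-3 cells (Homo sapiens) for cytotoxicity, read by sulforhodamine B assay, with a stated time of 72 h; on this read-out lower numbers stand for stronger inhibition of growth and higher numbers for weaker inhibition of growth. Compound 1 `O=C(Nc1ccccc1O)C1CCc2ccccc2N1C(=O)c1ccc(Cl)cc1` gives 13400 nM and compound 2 `CCCC(=O)N1c2ccccc2CCC1C(=O)Nc1cc(C(F)(F)F)cc(C(F)(F)F)c1` gives 14400 nM. Compound 3 `CCCC(=O)N1c2ccccc2CCC1C(=O)Nc1ccccc1C(F)(F)F` reaches only the limit of the measurement, > 70000 nM, so no number is known for it. Of the three values shown, one sits at this limit (the limit of > 70000 nM in this assay, at which 1 of the 3 values shown sits). Compound 4 `CCC(=O)N1c2ccccc2CCC1C(=O)Nc1ccccc1C(F)(F)F` is the compound still to be measured; it differs from compound 3 by hydrogen in place of methyl on a saturated chain carbon, two bonds along the chain from a carbonyl carbon. For the measured compounds named here, with no measured pair showing such a step, the expectation is a change no larger than the scatter, so compound 4 is expected to stay near the limit as well, estimated at 70000 nM with a range from 30000 nM to 200000 nM. That estimate means a step of a number no higher from compound 3 to compound 4 (the limit leaves the size open), expected to lie within the scatter.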

Compound 4, concentration for 50% growth inhibition: > 80000 nM
Compound 4: no number, only a limit; the forecaster's own chance of this, stated with the estimate: 60%; middle value at least 1.1-fold (0.05 log units) from the limit.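

Compound 3 and compound 4 each give only a limit, not a number, so the step between them cannot be read. Going by these compounds, whether hydrogen in place of methyl changes growth inhibition at all stays open.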